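A few compounds are considered here, and "the series" means these few. Any claim that something is new, unique, unknown or untested is made for them only; others in the source may bear on it.

In an ADME assay on microsomes from liver (Homo sapiens) for metabolic stability, using NADPH, with a stated time of 60 min (on this read-out lower numbers stand for slow clearance and higher numbers for fast clearance), three compounds built on one shared core have been examined. Compound 1 `O=C(Nc1ccnc(C(F)(F)F)c1)Nc1ccnc(C(F)(F)F)c1` returns < 7 uL/min, which is a limit of the assay rather than a number. Compound 2 `O=C(Nc1ccc(F)c(C(F)(F)F)c1)Nc1cnccn1` gives 210 uL/min. Compound 3 `O=C(Nc1ccc(F)c(C(F)(F)F)c1)Nc1ccccn1` gives 188 uL/min, the lowest of the two numbers actually reported; the step of a 1.1-fold lower number from compound 2 to compound 3 (0.05 log units; within the scatter) is within the scatter, so the two values cannot be told apart. Compound 4 `O=C(Nc1cccnc1)Nc1ccc(F)c(C(F)(F)F)c1` has not yet been measured in this assay. Its difference from compound 3 is pyridin-3-yl in place of pyridin-2-yl on an amide-type nitrogen. For the measured compounds named here, only one measured step touches the same amide-type nitrogen, a 1.1-fold lower number from compound 2 to compound 3 (0.05 log units; within the scatter), and that exchange of pyrazin-2-yl for pyridin-2-yl left both values within the scatter of each other. Going by the values given here, no measured pair shows the pyridin-3-yl group itself. On this basis the step of a 1.0-fold lower number from compound 3 to compound 4 (0.02 log units; within the scatter) is expected to remain within the scatter, with no direction favoured. Compound 4 is therefore estimated at 180 uL/min, with a range from 90 uL/min to 360 uL/min.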

Compound 4, intrinsic clearance in a liver preparation (reported as CLH), per the amount of preparation that the assay uses in the Homo sapiens assay: 13 uL/min
Compound 4: the middle estimate sits 14-fold (1.14 log units) above what was measured; the measured number lies below the stated range.
By their numbers in the Homo sapiens assay, from the lowest: compound 4; then compounds 3 and 2 (each within the scatter of the next). At a limit, below all of these: compound 1.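

In the Homo sapiens assay, pyridin-3-yl on the amide-type nitrogen gives a 14-fold lower number from compound 3 to compound 4 (1.16 log units; beyond the scatter) and a 16-fold lower number from compound 2 to compound 4 (1.21 log units; beyond the scatter), so this place, where compound 2 and compound 3 could not be told apart, proves highly sensitive to which ring it carries, even when the atoms stay the same and are only joined differently. In a physicochemical assay for lipophilicity, read by HPLC, measured as octanol-water partition, at pH 7.2 (on this read-out higher numbers stand for higher lipophilicity and lower numbers for lower lipophilicity), compound 3 gives 3.7 and compound 4 gives 3. The much slower clearance of compound 4 may owe something to its lower lipophilicity, although a single pair cannot establish this: the measured distribution coefficient of compound 3, 3.7, and of compound 4, 3, a number 0.70 log units lower (beyond the scatter)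

Going by these compounds, whether a pyridin-4-yl group, or a pyridin-3-yl group bearing an amine, would keep clearance this low remains open. How much of the fall in clearance follows the distribution coefficient, rather than the exchange of rings itself, also remains undecided.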